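Replacing methylamino with 4-ethylpiperazin-1-yl on the core

The source may report more compounds than this note shows. Statements on the series, on what has been measured and on what is new or still open speak of the compounds shown alone.

Compound 3 `CNc1cc(C)c2cc(NC(=O)c3ccc(Cl)c(Cl)c3)ccc2n1` gives the lowest number of the three compounds measured in a functional assay on SK-BR-3 cells (Homo sapiens) for antiproliferative activity, read by MTT assay, with a stated time of 72 h (on this read-out higher numbers stand for weaker inhibition and lower numbers for stronger inhibition), at 6350 nM. Compound 2 `CCN1CCN(c2cc(C)c3cc(NC(=O)c4ccccc4OC)ccc3n2)CC1` gives 15700 nM in this assay, and compound 1 `Cc1cc(N2CCCCC2)nc2ccc(NC(=O)c3ccc(Cl)c(Cl)c3)cc12` gives 42500 nM. Compound 4 `CCN1CCN(c2cc(C)c3cc(NC(=O)c4ccc(Cl)c(Cl)c4)ccc3n2)CC1` differs from compound 3 by 4-ethylpiperazin-1-yl in place of methylamino on an aromatic carbon. For the measured compounds named here, the one measured step that bears on this change runs the other way: a 6.7-fold lower number from compound 1 to compound 3 (0.83 log units; beyond the scatter), so moving back from methylamino to a ring group is expected to raise the number. Compound 2, which carries the same 4-ethylpiperazin-1-yl group beside a different amide, sits at 15700 nM, pointing the same way. Compound 4 is therefore expected to give 22000 nM in this assay, within 8000 nM to 60000 nM, an expected step of a 3.5-fold higher number from compound 3 to compound 4 (0.54 log units; beyond the scatter).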

Compound 4, half-maximal inhibitory concentration: 2160 nM
The estimate for compound 4 lay 10-fold (1.01 log units) above the measured number; the whole stated range lies above it.
By their numbers in this assay, from the lowest: compound 4; then compound 3; then compound 2; then compound 1.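

In this assay, a ring group on this aromatic carbon is not in itself worse than methylamino: 4-ethylpiperazin-1-yl gives a 2.9-fold lower number from compound 3 to compound 4 (0.47 log units; beyond the scatter) and so reverses the direction seen with piperidin-1-yl. The two ring groups stand far apart, with a 20-fold lower number from compound 1 to compound 4 (1.29 log units; beyond the scatter) on the same dichlorinated amide, so the outcome here depends on which ring enters. With 4-ethylpiperazin-1-yl held fixed, 3,4-dichlorophenyl in place of 2-methoxyphenyl gives a 7.3-fold lower number from compound 2 to compound 4 (0.86 log units; beyond the scatter) as a further gain from the amide side. From the compounds shown here alone, how piperazin-1-yl without the ethyl group or morpholin-4-yl would compare stays open. Nothing measured here accounts for these steps.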